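Compound 1 to compound 4: replacing 4-aminophenyl

The compounds below may be only part of what the source reports. "The series", "measured", "known", "first", "only" and "open" are said of these compounds alone.

In a functional assay on SR cells (Homo sapiens) for inhibition, read by sulforhodamine B assay, with a stated time of 48 h (a higher number here means a weaker inhibitor of growth, a lower number a stronger inhibitor of growth), compound 1 `COc1cc(-c2cc(/C=C/C(=O)c3ccc(N)cc3)[nH]n2)cc(OC)c1OC` gives 2750 nM, the lowest of the three measured numbers. Compound 2 `COc1cc(-c2cc(/C=C/C(=O)c3ccc(Cl)c(Cl)c3)[nH]n2)cc(OC)c1OC` gives 13500 nM, and compound 3 `COc1ccc(C(=O)/C=C/c2cc(-c3cc(OC)c(OC)c(OC)c3)n[nH]2)cc1` gives 23900 nM. Compound 4 `COc1cc(-c2cc(/C=C/C(=O)c3ccc(F)c(F)c3)[nH]n2)cc(OC)c1OC` is not yet measured. It differs from compound 1 by 3,4-difluorophenyl in place of 4-aminophenyl on a carbonyl carbon.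

The closest measured change is 3,4-dichlorophenyl in place of 4-aminophenyl, which gives a 4.9-fold higher number from compound 1 to compound 2 (0.69 log units; beyond the scatter). Methoxy in place of amino gives an 8.7-fold higher number from compound 1 to compound 3 (0.94 log units; beyond the scatter). The remaining pair shows a 1.8-fold higher number from compound 2 to compound 3 (0.25 log units; within the scatter). Going by the values given here, both measured departures from compound 1 therefore raise the number, though no measured compound carries 3,4-difluorophenyl.

Among the compounds with values here, a modest step to a higher number is expected in this assay, close in size to the one seen with compound 2 at 13500 nM. The expected step is a 4.7-fold higher number from compound 1 to compound 4 (0.67 log units; beyond the scatter). For compound 4 the estimated value is 13000 nM, with an expected range from 5000 nM to 32000 nM.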

Compound 4, concentration for total growth inhibition: > 100000 nM
Compound 4 was reported as a limit; the forecaster's own chance of this, stated with the estimate: 5%; at least 7.6-fold (0.88 log units) between middle value and limit.
By their numbers in this assay, from the lowest: compound 1; then compounds 2 and 3 (each within the scatter of the next). At a limit, above all of these: compound 4.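

In this assay compound 4 gives a limit, not a number: the limit of > 100000 nM in this assay, at which 1 of the 4 values shown sits. 3,4-difluorophenyl in place of 4-aminophenyl gives an at least 36-fold higher number from compound 1 to compound 4 (1.56 log units; beyond the scatter). The group on the carbonyl carbon can therefore shift the reading much further than compounds 2 and 3 showed. The two dihalogenated compounds also do not read alike: 3,4-difluorophenyl in place of 3,4-dichlorophenyl gives an at least 7.4-fold higher number from compound 2 to compound 4 (0.86 log units; beyond the scatter), and 3,4-difluorophenyl in place of 4-methoxyphenyl gives an at least 4.1-fold higher number from compound 3 to compound 4 (0.62 log units; beyond the scatter).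

Still open, from the compounds shown here alone, is how 4-fluorophenyl or 4-hydroxyphenyl on the same carbonyl carbon would read, and so whether the amino group itself accounts for the low number of compound 1. Going by these compounds, the full size of each step to compound 4 also remains unknown.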